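The compounds below may be only part of what the source reports. "The series", "measured", "known", "first", "only" and "open" are said of these compounds alone.

Among the measured compounds shown here, in a functional assay (muscle tissue) with Cavia porcellus as the target (a lower number here means that less compound is needed, a higher number that more compound is needed for the effect), compound 3 `COC(=O)C1=C(C)N=C(C)/C(=C(\O)OC)C1c1ccccc1Br` gives 7.59 nM, the lowest of the three numbers so far, against compound 1 `COC(=O)C1=C(C)N=C(C)/C(=C(\O)OC)C1c1cccc(OC)c1` at 191 nM and compound 2 `COC(=O)C1=C(C)N=C(C)/C(=C(\O)OC)C1c1cccc(O)c1` at 1000 nM. The next change leads to compound 4 `COC(=O)C1=C(C)N=C(C)/C(=C(\O)OC)C1c1cccc(Cl)c1Cl`: 2,3-dichlorophenyl in place of 2-bromophenyl on a saturated ring carbon.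

Two large steps bear on this site: a 25-fold lower number from compound 1 to compound 3 (1.40 log units; beyond the scatter) and a 130-fold lower number from compound 2 to compound 3 (2.12 log units; beyond the scatter). Both show that the group at this carbon can move this assay strongly. The modest step of a 5.2-fold higher number from compound 1 to compound 2 (0.72 log units; beyond the scatter) shows a smaller change from hydrogen in place of methyl on an oxygen. For the measured compounds named here, none of these compares one halogen pattern with another, and no measured compound carries chlorine. Compound 4 keeps a halogen-bearing phenyl without an oxygen substituent, so it is expected to stay close to compound 3 at 7.59 nM, with no step beyond the scatter in either direction. The expected step is a 1.3-fold lower number from compound 3 to compound 4 (0.10 log units; within the scatter). Compound 4 is estimated at 6 nM, with an expected range of 2 nM to 20 nM.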

Compound 4, half-maximal effective concentration: 19.1 nM
Compound 4: middle estimate off by 3.2-fold (0.50 log units), on the low side; the range from low to high includes it.
By their numbers in this assay, from the lowest: compound 3; then compound 4; then compound 1; then compound 2.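

In this assay, among the compounds shown here, this is the first comparison of one halogen pattern with another at the saturated ring carbon: a 2.5-fold higher number from compound 3 to compound 4 (0.40 log units; beyond the scatter) shows that 2,3-dichlorophenyl and 2-bromophenyl are not equivalent here, although this step is smaller than either step from the oxygen-bearing phenyl groups to compound 4. Those steps are a 10-fold lower number from compound 1 to compound 4 (1.00 log units; beyond the scatter) and a 52-fold lower number from compound 2 to compound 4 (1.72 log units; beyond the scatter) so, among these four compounds, both halogen-bearing phenyl groups give lower numbers than both oxygen-bearing ones, and no compound goes against this order. The data shown offer no evidence that explains the step from 2-bromophenyl to 2,3-dichlorophenyl.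

As far as these compounds go, the exchange of bromine for chlorine and the presence of a second halogen change together in compound 4, so their separate contributions remain open. From the compounds shown here alone, the effect of an amine or a carboxylic acid on the phenyl ring at this carbon also remains open.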